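The source may report more compounds than this note shows. Statements on the series, on what has been measured and on what is new or still open speak of the compounds shown alone.

Measured so far:
- compound 1, `CCOC(=O)C1=C(N/C=N/c2cccnc2Cl)Nc2[nH]nc(C)c2C1c1ccc(N(C)C)cc1`: 4890 nM
- compound 2, `CCOC(=O)C1=C(NN=C(C(C)=O)C(C)=O)Nc2[nH]nc(C)c2C1c1ccc(N(C)C)cc1`: 8480 nM
- compound 3, `CCOC(=O)C1=C(N/N=C(/Cl)C#N)Nc2[nH]nc(C)c2C1c1ccc(N(C)C)cc1`: 23600 nM

All three share one core and differ only in the group carried on the amine nitrogen. In a functional assay on HepG2 cells (Homo sapiens) for inhibition, read by MTT assay, with a stated time of 48 h (a lower number here means a stronger inhibitor, a higher number a weaker inhibitor), compound 1 gives the lowest of the three numbers, but its distance to compound 2 is small, a 1.7-fold higher number from compound 1 to compound 2 (0.24 log units; within the scatter), so no order between compound 1 and compound 2 can be read. Compound 3 sits further away: a 4.8-fold higher number from compound 1 to compound 3 (0.68 log units; beyond the scatter) and a 2.8-fold higher number from compound 2 to compound 3 (0.44 log units; beyond the scatter).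

Compound 4, `CCOC(=O)C1=C(N/C=N/c2ccc([N+](=O)[O-])cc2)Nc2[nH]nc(C)c2C1c1ccc(N(C)C)cc1`, keeps the group on the amine nitrogen of compound 1 intact and changes only the aryl at its far end: 4-nitrophenyl in place of 2-chloropyridin-3-yl on a double-bonded nitrogen. Among the measured compounds shown here, none of the measured steps touches this position; each of them swaps the whole group on the amine nitrogen, and the largest of them, a 4.8-fold higher number from compound 1 to compound 3 (0.68 log units; beyond the scatter), is still only modest. For the measured compounds named here, the measured series therefore gives no direct precedent, only the observation that the whole region tolerates replacement with modest shifts. On that basis the change from compound 1 to compound 4 is expected to move the number little, a 1.1-fold higher number from compound 1 to compound 4 (0.05 log units; within the scatter), with the direction uncertain.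

Compound 4 is accordingly estimated at 5500 nM in this assay, with a range from 2000 nM to 16000 nM.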

Compound 4, half-maximal inhibitory concentration: 50900 nM
Compound 4: middle estimate off by 9.3-fold (0.97 log units), on the low side; measured number above the stated range.
By their numbers in this assay, from the lowest: compounds 1 and 2 (each within the scatter of the next); then compound 3; then compound 4.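

In this assay, among the compounds shown here, the aryl at the far end of the group is not a silent place: 4-nitrophenyl in place of 2-chloropyridin-3-yl on the double-bonded nitrogen gives the only large step (a 10-fold higher number from compound 1 to compound 4 (1.02 log units; beyond the scatter)), although the rest of the group on the amine nitrogen stays intact. Compound 4 also stands clear of the two compounds with no ring in this group (a 2.2-fold higher number from compound 3 to compound 4 (0.33 log units; beyond the scatter); a 6.0-fold higher number from compound 2 to compound 4 (0.78 log units; beyond the scatter)), yet compound 1 and compound 4 both carry an aromatic ring here and are still separated by the large step, so the presence of a ring does not order the series. No measurement at hand gives a reason for this step.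

The two aryls differ at once in the ring nitrogen, the chlorine and the nitro group, so the compounds shown cannot assign the step to any one of these features. From the compounds shown here alone, how a plain phenyl or an aminophenyl on the same double-bonded nitrogen would read remains open.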